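This account rests on a few compounds, and the source may have more. Where it says the series, first, only, none or still open, it means among the compounds named here.

Measured compounds in a functional assay on CHO cells with adenosine receptor A1 (Homo sapiens) as the target, read by cAMP accumulation and immunoassay, with a stated time of 6 min, tested at 0.01 uM; a higher number here means a weaker effect of the compound at the concentration tested, a lower number a stronger effect:
- compound 1, `Nc1scc(CN2CCN(c3ccc(Cl)c(C(F)(F)F)c3)CC2)c1C(=O)c1ccc(Cl)cc1`: -2.5%
- compound 2, `Nc1scc(CN2CCN(c3cccnc3)CC2)c1C(=O)c1ccc(Cl)cc1`: 3.2%
- compound 3, `Nc1scc(CN2CCN(c3ccc(F)cc3F)CC2)c1C(=O)c1ccc(Cl)cc1`: 0%

All three numbers sit close to zero. Compound 1 stands alongside compounds 2 and 3: the steps of a number 5.7 percentage points higher from compound 1 to compound 2 (within the scatter) and a number 2.5 percentage points higher from compound 1 to compound 3 (within the scatter) both fall within the scatter, as does a number 3.2 percentage points lower from compound 2 to compound 3 (within the scatter), so the three are indistinguishable in this assay and none can be called stronger or weaker than another.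

Compound 4, `Nc1scc(CN2CCN(CCCc3ccc(Cl)cc3)CC2)c1C(=O)c1ccc(Cl)cc1`, differs from compound 1 at the same place where compounds 2 and 3 differ from it, the aryl group on an amine nitrogen in a ring: 3-(4-chlorophenyl)propyl in place of 4-chloro-3-(trifluoromethyl)phenyl on an amine nitrogen in a ring. Among the measured compounds shown here, the steps that bear on it are those changing the same group, from compound 1 to compound 2 and from compound 1 to compound 3, and both are within the scatter. For the measured compounds named here, no measured step at this position moves the number beyond the scatter, so a step of no size beyond the scatter is expected here too, with a number 2.5 percentage points higher from compound 1 to compound 4 (within the scatter) as the expected step. For compound 4 the estimate in this assay is 0%, with a range from -10% to 10%.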

Compound 4, a percentage reported as activity, at one concentration (the size of the read-out at that concentration, not a potency): 0%
Beside the measured number, compound 4's estimate shows no gap at the digits printed; measured number inside the range.
By their numbers in this assay, from the lowest: compounds 1, 3, 4 and 2 (each within the scatter of the next).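

Until now this amine nitrogen had carried only groups with the aromatic ring bonded directly to it, whereas 3-(4-chlorophenyl)propyl places a propyl chain there. The steps of a number 2.5 percentage points higher from compound 1 to compound 4 (within the scatter) and no change at the digits printed from compound 3 to compound 4 (within the scatter) and a number 3.2 percentage points lower from compound 2 to compound 4 (within the scatter) show that, in this assay, this chain does not separate compound 4 from the three directly attached aryl groups. The data on hand give no explanation for this lack of separation.

Still open, on these data alone, is whether a primary amine or a carboxylic acid at the end of a longer chain on this nitrogen would move the number beyond the scatter. The four compounds also share the rest of the core, so they say nothing about changes elsewhere, or about how these compounds compare at concentrations other than the one tested.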